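A few compounds are considered here, and "the series" means these few. Any claim that something is new, unique, unknown or untested is made for them only; others in the source may bear on it.

Within the data shown here, compound 1 `Cc1cc(-c2ccccc2)n(/C(N)=N/S(=O)(=O)c2cc(C)c(Cl)cc2SCc2cccc3ccccc23)n1` is one of three compounds measured in a functional assay on HeLa cells (Homo sapiens) for cytotoxicity, read by MTT assay, with a stated time of 72 h (on this read-out lower numbers stand for stronger inhibition and higher numbers for weaker inhibition), and on that read-out compound 1 gives 3000 nM, the lowest of the three numbers. Compound 2 `Cc1cc(S(=O)(=O)/N=C(\N)n2nccc2-c2ccccc2)c(SCc2ccccc2C)cc1Cl` gives 17000 nM, and compound 3 `Cc1cc(S(=O)(=O)/N=C(\N)n2nccc2-c2ccccc2)c(SCc2ccccc2C(F)(F)F)cc1Cl` gives 20000 nM; both stand beyond the scatter above compound 1. Among the measured compounds shown here, the one single-point step among the measured compounds, a 1.2-fold higher number from compound 2 to compound 3 (0.07 log units; within the scatter), runs between compounds whose core differs from that of compound 1, and it moves nothing beyond the scatter.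

Compound 4 `Cc1cc(-c2ccccc2)n(/C(N)=N/S(=O)(=O)c2cc(C)c(Cl)cc2SCc2ccccc2Cl)n1` is compound 1 with one change: 2-chlorophenyl in place of naphthalen-1-yl on a saturated chain carbon bound to a sulfur. For the measured compounds named here, no measured step covers this exchange directly. What the numbers show is that compound 1, carrying (naphthalen-1-yl)methyl on the sulfur, sits well below compounds 2 and 3, which carry 2-methylbenzyl and 2-(trifluoromethyl)benzyl there on a different core. Compound 4 is therefore expected to come out with a higher number, a step of a 2.7-fold higher number from compound 1 to compound 4 (0.43 log units; beyond the scatter), though with wide uncertainty. The estimate for compound 4 in this assay is 8000 nM, between 3000 nM and 25000 nM.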

Compound 4, half-maximal inhibitory concentration: 270000 nM
Compound 4: the middle estimate sits 34-fold (1.53 log units) below what was measured; the measured number lies above the stated range.
By their numbers in this assay, from the lowest: compound 1; then compounds 2 and 3 (each within the scatter of the next); then compound 4.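

In this assay, the exchange on a saturated chain carbon bound to a sulfur is far from neutral: 2-chlorophenyl in place of naphthalen-1-yl gives a 90-fold higher number from compound 1 to compound 4 (1.95 log units; beyond the scatter) with the rest of the structure unchanged. Among these compounds, this is the first direct reading of this position, and it ties the lower number of compound 1 to the naphthalen-1-yl group, with two six-membered aromatic rings of carbon only, over the 2-chlorophenyl group, with one. Nothing available here bears on the reason for a step of this size.

Going by these compounds, it remains open whether the step follows the loss of the second ring or the arrival of the chlorine; a plain phenyl or a naphthalen-2-yl at this place on the core of compound 1 would help separate the two. On these data alone, whether the same exchange gives a step of similar size on the core of compound 2 also stays open.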